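The source may report more compounds than this note shows. Statements on the series, on what has been measured and on what is new or still open speak of the compounds shown alone.

Within the data shown here, in a physicochemical assay for solubility, measured as kinetic solubility, with a stated time of 15 h, at pH 7.4 (on this read-out lower numbers stand for lower solubility and higher numbers for higher solubility), compound 1 `O=[N+]([O-])c1ccc(-c2ccc(O[C@H]3O[C@H](CO)[C@@H](O)[C@H](O)[C@@H]3O)c(Cl)c2)cc1` gives 117 ug/mL, the highest of the three numbers measured so far. Compound 2 `OC[C@H]1O[C@H](Oc2ccc(-c3ccc(Cl)c(Cl)c3)cc2Cl)[C@@H](O)[C@@H](O)[C@@H]1O` gives 2.3 ug/mL, and compound 3 `OC[C@H]1O[C@H](Oc2ccc(-c3ccc(Cl)c(C(F)(F)F)c3)cc2Cl)[C@@H](O)[C@@H](O)[C@@H]1O` gives 1 ug/mL.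

The next compound, compound 4 `CC(=O)c1ccc(-c2ccc(O[C@H]3O[C@H](CO)[C@@H](O)[C@H](O)[C@@H]3O)c(Cl)c2)cc1`, has not yet been measured. It differs from compound 1 at one place, with acetyl in place of nitro on an aromatic carbon. The same change can be read as 4-nitrophenyl to 4-acetylphenyl.

Neither measured step makes this exact swap, so both offer only a sense of scale. Putting 3,4-dichlorophenyl in place of 4-nitrophenyl gave a 51-fold lower number from compound 1 to compound 2 (1.71 log units; beyond the scatter), a large step that exchanged the same 4-nitrophenyl group that changes here. Putting trifluoromethyl in place of chloro then gave a 2.3-fold lower number from compound 2 to compound 3 (0.36 log units; beyond the scatter), a modest step. The change to compound 4 replaces only the nitro group and leaves the rest of that ring as it is, so it is closer in kind to the modest step than to the large one. A small fall is therefore expected, and it may not rise beyond the scatter. The expected step is a 1.5-fold lower number from compound 1 to compound 4 (0.17 log units; within the scatter). For compound 4 the estimated value is 80 ug/mL, within an expected range of 25 ug/mL to 200 ug/mL.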

Compound 4, solubility: 16 ug/mL
Estimate against measurement, compound 4: 5.0-fold (0.70 log units) above; the whole stated range lies above it.
By their numbers in this assay, from the lowest: compound 3; then compound 2; then compound 4; then compound 1.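

Exchanging only nitro for acetyl, on an aromatic carbon para to a large group, is enough to move the number in this assay by a step beyond the scatter: a 7.3-fold lower number from compound 1 to compound 4 (0.86 log units; beyond the scatter). This happens even though both groups have 3 heavy atoms, no ring and 1 double bond outside aromatic rings, while the counts differ in hydrogen-bond acceptors, with 2 for nitro and 1 for acetyl. The larger exchange of the whole ring also reads differently now, since 4-acetylphenyl in place of 3,4-dichlorophenyl gives a 7.0-fold higher number from compound 2 to compound 4 (0.84 log units; beyond the scatter), which shows that compound 4 keeps a clear margin over compound 2 despite its fall from compound 1, and no measurement at hand accounts for either step.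

The compounds shown leave open how an amine or a carboxylic acid on this same aromatic carbon would read in this assay. They also leave open whether the step from nitro to acetyl would keep its size on a core other than that of compound 1.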